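Swapping the aryl group on a weak antiproliferative scaffold

A few compounds are considered here, and "the series" means these few. Any claim that something is new, unique, unknown or untested is made for them only; others in the source may bear on it.

Compound 1 `CN(c1cccc2c1CN(c1nc(Nc3cc(C(F)(F)F)cc(C(F)(F)F)c3)ncc1C(F)(F)F)C2)S(C)(=O)=O`: > 30000 nM (a limit of the assay)
Compound 2 `Cc1cc(Cl)ccc1Nc1ncc(C(F)(F)F)c(N2Cc3cccc(N(C)S(C)(=O)=O)c3C2)n1`: 25500 nM

For the measured compounds named here, in a functional assay on A549 cells (Homo sapiens) for antiproliferative activity, read by spectrophotometry, with a stated time of 2 days (on this read-out higher numbers stand for weaker inhibition of growth and lower numbers for stronger inhibition of growth), compound 2 gives 25500 nM, the only true number among the two values shown. Compound 1 is reported as > 30000 nM, which is a limit of the assay and not a measured number. Both compounds therefore sit at the weak end of this assay, and compound 2 stands as the single fixed point.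

Compound 3 `CN(c1cccc2c1CN(c1nc(Nc3ccc(Cl)c(C(F)(F)F)c3)ncc1C(F)(F)F)C2)S(C)(=O)=O` is not yet measured. It differs from compound 2 in one place: 4-chloro-3-(trifluoromethyl)phenyl in place of 4-chloro-2-methylphenyl on a nitrogen on an aromatic ring. Compound 1, which also carries trifluoromethyl groups on its aryl ring, sits at the limit of > 30000 nM in this assay, at which 1 of the 2 values shown sits, so a move towards weaker inhibition or no change beyond the scatter seems most likely. The expected step is a 1.2-fold higher number from compound 2 to compound 3 (0.07 log units; within the scatter), with a fair chance that only a limit is returned. Compound 3 is estimated at 30000 nM, within a range from 10000 nM to 100000 nM.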

Compound 3, concentration for 50% growth inhibition: 15200 nM
For compound 3 the middle estimate is 2.0-fold (0.30 log units) above the measured one; the range from low to high includes it.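

In this assay, placing 4-chloro-3-(trifluoromethyl)phenyl in the position of 4-chloro-2-methylphenyl on this nitrogen gives a 1.7-fold lower number from compound 2 to compound 3 (0.22 log units; within the scatter), so the two compounds cannot be told apart. The aryl group here can therefore change from 8 to 11 heavy atoms, and take on a trifluoromethyl group, while the result stays a true number at the same weak level. Compound 1 remains a limit of the assay and not a number: the limit of > 30000 nM in this assay, at which 1 of the 3 values shown sits.

The compounds shown leave open whether a different kind of group on this nitrogen, such as a pyridine ring or a phenyl ring carrying an amine or a carboxylic acid, would move the number beyond the scatter. They also leave open whether the shared core can reach stronger inhibition of growth at all.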